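Cytotoxicity notes: cyclobutyl replacing isopropylsulfonyl on compound 2

The source may report more compounds than this note shows. Statements on the series, on what has been measured and on what is new or still open speak of the compounds shown alone.

The series is followed in an ADME assay on HEp-2 cells (Homo sapiens) for cytotoxicity; a higher number here means that more compound is tolerated, a lower number that less compound is tolerated. Compound 1 `CS(=O)(=O)c1ccc(Cn2c(=O)n(Cc3nc4ccccc4n3CCCC#N)c3ccncc32)cc1` gives 40900 nM in this assay. Compound 3 `CC(C)S(=O)(=O)CCCn1c(Cn2c(=O)n(C3CC3)c3ccncc32)nc2ccccc21` gives 49200 nM in this assay, and these two values lie within the usual scatter of each other, so no order is read between them. Compound 2 `CC(C)S(=O)(=O)n1c(=O)n(Cc2nc3ccccc3n2CCCC#N)c2cnccc21` reaches only the limit of the assay in this assay, > 228000 nM, which is a limit and not a number (the limit of > 228000 nM in this assay, at which 1 of the 3 values shown sits). Compound 4 `N#CCCCn1c(Cn2c(=O)n(C3CCC3)c3ccncc32)nc2ccccc21` has not yet been measured in this assay. It differs from compound 2 in one place: cyclobutyl in place of isopropylsulfonyl on an aromatic nitrogen. Within the data shown here, no measured pair tells the size of such a change directly. Compound 1 and compound 3, which carry other groups at that aromatic nitrogen, both sit at numbers rather than at the limit. On that basis a downward step beyond the scatter, toward less compound tolerated, is expected: an at least 4.1-fold lower number from compound 2 to compound 4 (0.61 log units; beyond the scatter). Compound 4 is expected to give about 55000 nM in this assay, with a range from 22000 nM to 150000 nM, with some chance that only a limit is returned.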

Compound 4, half-maximal cytotoxic concentration: > 258000 nM
Compound 4 ended at the assay's limit; the forecaster's own chance of this, stated with the estimate: 15%; middle value at least 4.6-fold (0.67 log units) from the limit.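

Compound 2 and compound 4 both return limits and not numbers in this assay, so no step can be read for cyclobutyl in place of isopropylsulfonyl on an aromatic nitrogen. The compounds shown leave open how much compound either one tolerates past its limit, and whether this exchange changes the read-out at all.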